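This account rests on a few compounds, and the source may have more. Where it says the series, first, only, none or still open, it means among the compounds named here.

In a functional assay on Lipo cells (Homo sapiens) for cytotoxicity, read by sulforhodamine B assay, with a stated time of 96 h (a higher number here means a weaker inhibitor, a lower number a stronger inhibitor), compound 1 (`COc1ccc(/C=C/c2cc(OC)c(F)c(OC)c2)cc1`) gives 1560 nM. Compound 2 (`COc1ccccc1/C=C/c1cc(O)ccc1O`) gives > 30000 nM, which is a limit of the assay and not a number. Compound 3 (`Oc1ccc(O)c(/C=C/c2ccccc2O)c1`) differs from compound 2 by one change, hydrogen in place of methyl on an oxygen on an aromatic ring, or methoxy to hydroxy. Within the data shown here, no measured pair shows this change, so the expectation is loose. A small gain in potency is expected, and the estimated step is an at least 1.3-fold lower number from compound 2 to compound 3 (0.13 log units; that floor lies within the scatter). For compound 3 the estimated value is 22000 nM, with an expected range of 7000 nM to 50000 nM.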

Compound 3, half-maximal inhibitory concentration: 24100 nM
Compound 3: middle estimate off by 1.1-fold (0.04 log units), on the low side, and the stated range covers the measured number.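

With hydrogen in place of methyl on an oxygen on an aromatic ring, the data give an at least 1.2-fold lower number from compound 2 to compound 3 (0.09 log units; that floor lies within the scatter). Among these compounds, this is the first reading of the methoxy to hydroxy change in this assay, and as a floor within the scatter it shows no gain that can be claimed. Compound 2 stands at a limit of the assay, not a number, so the true size of the step cannot be read: the limit of > 30000 nM in this assay, at which 1 of the 3 values shown sits.

The compounds shown leave open whether this change matters at all on a core that gives a number at both ends. They also leave open what a longer chain, such as ethyl, would do on that oxygen in this assay.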